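What Losing One Methoxy Group Might Change

This account rests on a few compounds, and the source may have more. Where it says the series, first, only, none or still open, it means among the compounds named here.

Of the compounds shown here, two built on the same core have been measured so far in an ADME assay on HEK293 cells (Homo sapiens) for cytotoxicity, read by resazurin assay, with a stated time of 16 h; on this read-out higher numbers stand for an effect only at larger amounts of compound and lower numbers for an effect already at smaller amounts. Compound 2 (`COc1cc(/C=C/C(=O)CC(=O)/C=C/c2ccc(OC(=O)c3ccccc3)c(OC)c2)ccc1O`) stands higher of the two at 94000 nM while compound 1 (`COc1cc(/C=C/C(=O)CC(=O)/C=C/c2ccc(OCCO)cc2)ccc1O`) sits at 46000 nM and that gap lies just beyond the usual scatter of repeat measurements.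

Compound 3 (`COc1cc(/C=C/C(=O)CC(=O)/C=C/c2ccc(OC(=O)c3ccccc3)cc2)ccc1O`) has not been measured yet. Compared with compound 2, it carries hydrogen in place of methoxy on an aromatic carbon, ortho to a benzoyloxy group (hydrogen in place of methoxy on an aromatic carbon). For the measured compounds named here, no measured pair isolates this change, so there is no direct precedent. Compound 1 also has no methoxy group at that place, but it differs from compound 2 in other ways too. The lower value of compound 1 at 46000 nM is therefore only a weak hint of the direction. A small move toward a lower number is expected, with a step no larger than the scatter. The estimated step of a 1.3-fold lower number from compound 2 to compound 3 (0.13 log units; within the scatter) reflects that expectation. For compound 3 the expected value is 70000 nM with an estimated range from 30000 nM to 150000 nM in this assay.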

Compound 3, half-maximal effective concentration: > 500000 nM
Compound 3: only a limit was reported; the forecaster's own chance of this, stated with the estimate: 15%; middle value at least 7.1-fold (0.85 log units) away from the limit.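

In this assay compound 3 gives > 500000 nM, and this is a limit of the assay, not a number. Hydrogen in place of methoxy on an aromatic carbon, ortho to a benzoyloxy group, gives an at least 5.3-fold higher number from compound 2 to compound 3 (0.72 log units; beyond the scatter), so this single place, which no earlier pair could isolate, clearly counts in this read-out, and losing the methoxy group moves the number upward. Benzoyl in place of 2-hydroxyethyl on an oxygen on an aromatic ring gives an at least 10-fold higher number from compound 1 to compound 3 (1.03 log units; beyond the scatter), which shows that the group on that oxygen counts as well, since the two compounds differ only there.

Both steps rest on a limit, so each gives only a smallest possible size, and the true size of neither is known: the limit of > 500000 nM in this assay, at which 1 of the 3 values shown sits. Also open, as far as these compounds go, is how other groups would behave at the place of the methoxy group, such as an amine or a longer chain ending in a carboxylic acid, and whether losing the methoxy group would move the number in the same way when 2-hydroxyethyl rather than benzoyl sits on the oxygen.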